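A Second Methoxy in a Weakly Antiproliferative Series

The source may report more compounds than this note shows. Statements on the series, on what has been measured and on what is new or still open speak of the compounds shown alone.

compound 1 `FC(F)(F)c1ccc(C2CC(c3ccccc3)=NN2c2ccc(-c3ccccc3)nn2)cc1`: 50000 nM
compound 2 `COc1ccc(C2=NN(c3ccc(-c4ccccc4)nn3)C(c3ccc(C(F)(F)F)cc3)C2)cc1`: 65000 nM
compound 3 `COc1ccc(C2=NN(c3ccc(-c4ccccc4)nn3)C(c3ccc(OC)cc3)C2)cc1`: > 100000 nM

In a functional assay on Caco-2 cells (Homo sapiens) for antiproliferative activity, read by MTT assay, with a stated time of 24 h (on this read-out higher numbers stand for weaker inhibition and lower numbers for stronger inhibition), compound 1 gives 50000 nM. Compound 2 differs from it by methoxy in place of hydrogen on an aromatic carbon and gives 65000 nM; the step of a 1.3-fold higher number from compound 1 to compound 2 (0.11 log units; within the scatter). For compound 3 this assay reports only a limit, > 100000 nM. The difference between the core of compound 3 and the core of compound 1 is not broken down here. Compound 4 `COc1ccc(C2=NN(c3ccc(-c4ccccc4)nn3)C(c3ccc(OC)cc3OC)C2)cc1` has not been measured; it differs from compound 3 by methoxy in place of hydrogen on an aromatic carbon. This is the same kind of change as that from compound 1 to compound 2, but there the place was para to a large group, whereas here it is ortho to a large group and meta to a methoxy group. Compound 4 is expected to give 110000 nM, a step that the limit leaves unreadable from compound 3 to compound 4, an expectation that rests on compound 3 sitting at the limit of > 100000 nM in this assay, at which 1 of the 3 values shown sits, and on the small earlier step.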

Compound 4, half-maximal inhibitory concentration: > 100000 nM
Compound 4 gave a limit, no number; the forecaster's own chance of this, stated with the estimate: 80%; the middle value is on the limit's open side.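

In this assay compound 4 gives only a limit, > 100000 nM. The steps that end in two limits cannot be read, so it is not shown whether methoxy in place of hydrogen carries over to this core from the one case with numbers at both ends, a 1.3-fold higher number from compound 1 to compound 2 (0.11 log units; within the scatter). The one readable new step, an at least 1.5-fold higher number from compound 2 to compound 4 (0.18 log units; that floor lies within the scatter), gives only a floor, and little room remains for reading such a change in this series: the limit of > 100000 nM in this assay, at which 2 of the 4 values shown sit.

The compounds shown leave open whether an amine or a carboxylic acid in place of the added methoxy would give a measurable number on this core. They also leave open what a methoxy in this place would do on the core of compound 1.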